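Methoxy in place of chloro on an inactive anilide

The compounds below may be only part of what the source reports. "The series", "measured", "known", "first", "only" and "open" are said of these compounds alone.

Compound 1 `O=C(COC(=O)/C=C/c1ccc(O)c(O)c1)Nc1ccc(Cl)cc1` was tested in a functional assay on BEL-7404 cells (Homo sapiens) for cytotoxicity, read by MTT assay, with a stated time of 72 h; a higher number here means a weaker inhibitor, a lower number a stronger inhibitor. In this assay compound 1 gives > 200000 nM, which is a limit of the assay and not a measured number. The other compound tested, compound 2 `COCOc1ccc(/C=C/C(=O)N2CCN(Cc3ccc(Cl)c(Cl)c3)CC2)cc1OCOC`, gives > 200000 nM in this assay, again only a limit. Going by the values given here, both values sit at the limit of > 200000 nM in this assay, at which 2 of the 2 values shown sit, so compound 1 cannot be placed in order against compound 2, and no step between measured compounds exists. Compound 3 `COc1ccc(NC(=O)COC(=O)/C=C/c2ccc(O)c(O)c2)cc1` differs from compound 1 by a single change: methoxy in place of chloro on an aromatic carbon. Among the compounds with values here, no measured pair differing only in this way is available, so the expectation rests on compound 1 alone, whose result is a limit. Compound 3 is expected to remain near that limit, with an estimated step that the limit leaves unreadable from compound 1 to compound 3 no larger than the scatter. The estimate for compound 3 is 250000 nM, between 80000 nM and 600000 nM.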

Compound 3, half-maximal inhibitory concentration: > 200000 nM
Compound 3: a limit, no number; the forecaster's own chance of this, stated with the estimate: 80%; the middle value is on the limit's open side.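

No step can be read from compound 1 to compound 3, because both results are only limits of the assay: the limit of > 200000 nM in this assay, at which 3 of the 3 values shown sit.

The compounds shown leave open whether chloro and methoxy differ at all in this assay, and which change to the shared core would give a measurable value.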